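Adding trifluoromethyl to compound 2: cytotoxicity notes

This account rests on a few compounds, and the source may have more. Where it says the series, first, only, none or still open, it means among the compounds named here.

compound 1 `FC(F)(F)c1ccc(NCc2cn(-c3ccccc3)nc2-c2ccc(Br)cc2)cc1` gives 20000 nM
compound 2 `Cc1ccc(-c2nn(-c3ccccc3)cc2CNc2ccccc2)cc1` gives > 100000 nM (a limit, not a number)

Among the compounds with values here, both results come from an ADME assay on BHK-21 cells (Mesocricetus auratus) for cytotoxicity, read by MTT assay, with a stated time of 72 h (on this read-out higher numbers stand for lower toxicity in this test and lower numbers for higher toxicity in this test), and no measured step links the two compounds. In this assay compound 2 gives > 100000 nM as a limit of the assay, so its true position is not known.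

The next compound is compound 3 `Cc1ccc(-c2nn(-c3ccccc3)cc2CNc2ccc(C(F)(F)F)cc2)cc1` and the structural change from compound 2 is trifluoromethyl in place of hydrogen on an aromatic carbon in which phenyl becomes 4-(trifluoromethyl)phenyl. Trifluoromethyl takes the place of hydrogen on an aromatic carbon.

Compound 1 also bears a trifluoromethyl and gives 20000 nM as a measured number, so a move toward lower numbers, meaning higher toxicity in this test, is expected. Within the data shown here, no measured step isolates this change, so the size remains uncertain and another limit result is possible. The expected change is an at least 3.3-fold lower number from compound 2 to compound 3 (0.52 log units; beyond the scatter) with the size resting on an estimate alone. For compound 3 the estimated value is 30000 nM with an expected range from 10000 nM to 100000 nM in the coming measurement.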

Compound 3, half-maximal cytotoxic concentration: 88000 nM
Estimate against measurement, compound 3: 2.9-fold (0.47 log units) below; the measured number falls inside the stated range.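

In this assay, the change from hydrogen to trifluoromethyl at this position, para to a large group, now has a measured end point, and the step reads an at least 1.1-fold lower number from compound 2 to compound 3 (0.05 log units; that floor lies within the scatter), so a real drop in the number is not established. Compound 2 stands at a limit of the assay and not at a number, and the size of this step can be read only as a floor because of that limit: the limit of > 100000 nM in this assay, at which 1 of the 3 values shown sits.

With trifluoromethyl kept in place, methyl in place of bromo on an aromatic carbon gives a 4.4-fold higher number from compound 1 to compound 3 (0.64 log units; beyond the scatter), so a second place in the series also moves the number, and trifluoromethyl alone does not account for the value of compound 1.

From the compounds shown here alone, whether trifluoromethyl at this position lowers the number by more than the scatter stays open while the value for compound 2 remains a limit. The compounds shown also leave open how a carboxylic acid or an amine would read at this same position, and how either would compare with trifluoromethyl in this assay.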